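Diol in place of aminomethyl-oxetane on the ether chain

A few compounds are considered here, and "the series" means these few. Any claim that something is new, unique, unknown or untested is made for them only; others in the source may bear on it.

Compound 3 `Cc1n[nH]c2nc(-c3ccc(NS(=O)(=O)c4cc(Cl)ccc4F)cc3)nc(OCC3(CN)COC3)c12` gives the lowest number of the three measured in an assay for inhibition of serine/threonine-protein kinase Sgk1 (Homo sapiens), with stated times of 30 min and 60 min, in the presence of a further agent that is not named here (on this read-out higher numbers stand for weaker inhibition and lower numbers for stronger inhibition), at 1 nM. Compound 1 `CCOc1nc(-c2ccc(NS(=O)(=O)c3cc(Cl)ccc3F)cc2)nc2[nH]nc(C)c12` gives 23 nM in this assay, and compound 2 `Cc1n[nH]c2nc(-c3ccc(NS(=O)(=O)c4cc(Cl)ccc4F)cc3)nc(OCCC(=O)N(C)C)c12` gives 15 nM. The step from compound 1 to compound 2 is a 1.5-fold lower number from compound 1 to compound 2 (0.19 log units; within the scatter); the steps into compound 3 are a 23-fold lower number from compound 1 to compound 3 (1.36 log units; beyond the scatter) and a 15-fold lower number from compound 2 to compound 3 (1.18 log units; beyond the scatter), both large. Compound 4 `Cc1n[nH]c2nc(-c3ccc(NS(=O)(=O)c4cc(Cl)ccc4F)cc3)nc(OCC(CO)CO)c12` is unmeasured; it differs from compound 3 by 2-hydroxy-1-(hydroxymethyl)ethyl in place of 3-(aminomethyl)oxetan-3-yl on a saturated chain carbon bound to an oxygen on an aromatic ring. For the measured compounds named here, no measured step carries this exact change. The two large steps both entered the group that now leaves, so the gain seen on arriving at compound 3 is not assured to carry over to compound 4; a move back toward the numbers of compound 1 and compound 2 is the nearest guide, though the entering group is not a plain hydrogen or methyl either, so the full return is not assumed. The estimate for compound 4 in this assay is therefore 8 nM, with a range of 2 nM to 40 nM, an expected step of an 8.0-fold higher number from compound 3 to compound 4 (0.90 log units; beyond the scatter) toward a weaker number.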

Compound 4, half-maximal inhibitory concentration: 1 nM
The estimate for compound 4 lay 8.0-fold (0.90 log units) above the measured number; measured number below the stated range.
By their numbers in this assay, from the lowest: compounds 3 and 4 (each within the scatter of the next); then compounds 2 and 1 (each within the scatter of the next).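

In this assay, the aminomethyl group and the oxetane ring can both leave this chain carbon without loss: 2-hydroxy-1-(hydroxymethyl)ethyl in place of 3-(aminomethyl)oxetan-3-yl gives no change at the digits printed from compound 3 to compound 4 (within the scatter). The gain over the smaller and amide-bearing chains therefore does not depend on a ring or a nitrogen in the group, since the open diol also shows a 15-fold lower number from compound 2 to compound 4 (1.18 log units; beyond the scatter) and a 23-fold lower number from compound 1 to compound 4 (1.36 log units; beyond the scatter). No measurement at hand accounts for this shared gain.

From the compounds shown here alone, whether both hydroxymethyl arms are required remains open, and a chain ending in a single hydroxyl would test this. Going by these compounds, it is also open whether a plain aminomethyl group without the oxetane ring, or a carboxylic acid on this chain carbon, would hold the number in this assay.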